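This account rests on a few compounds, and the source may have more. Where it says the series, first, only, none or still open, it means among the compounds named here.

Of the compounds shown here, three built on one shared core have been tested in an assay on cells for activation of Cystic fibrosis transmembrane conductance regulator (Homo sapiens), read by fluorescence, with stated times of 10 min and 12 s; on this read-out lower numbers stand for an effect already at smaller amounts and higher numbers for an effect only at larger amounts of compound. Compound 1 `CCN(CC)c1nc(Nc2cccc(C(=O)O)c2)nc(OC(C(F)(F)F)C(F)(F)F)n1` gives 160 nM. Compound 2 `CCN(CC)c1nc(Nc2ccc(F)cc2)nc(OC(C(F)(F)F)C(F)(F)F)n1` gives 700 nM. Compound 3 `CCN(CC)c1nc(Nc2ccc([N+](=O)[O-])cc2)nc(OC(C(F)(F)F)C(F)(F)F)n1` gives 18000 nM, the highest of the three numbers: its nearest neighbour is compound 2, and the gap between them is a 26-fold higher number from compound 2 to compound 3 (1.41 log units; beyond the scatter), while compound 1 lies furthest away, through a 110-fold higher number from compound 1 to compound 3 (2.05 log units; beyond the scatter).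

Compound 4 `CCN(CC)c1nc(Nc2ccc3ncoc3c2)nc(OC(C(F)(F)F)C(F)(F)F)n1` has not yet been measured. It differs from compound 3 in a single place: 1,3-benzoxazol-6-yl in place of 4-nitrophenyl on a nitrogen on an aromatic ring. The two measured steps that end at compound 3 both replace one aryl group with another on that same nitrogen, and both were large; the step of a 26-fold higher number from compound 2 to compound 3 (1.41 log units; beyond the scatter) is the closer comparison, since compound 2 and compound 4 both carry a neutral group without a donor there. Moving away from 4-nitrophenyl is therefore expected to bring the number down by a large margin, with the charged acid of compound 1 marking a further gain that compound 4 does not share. The estimated step is a 12-fold lower number from compound 3 to compound 4 (1.08 log units; beyond the scatter), giving for compound 4 an expected value of 1500 nM, in a range from 300 nM to 7000 nM.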

Compound 4, half-maximal effective concentration: 150 nM
Estimate against measurement, compound 4: 10-fold (1.00 log units) above; the whole stated range lies above it.
By their numbers in this assay, from the lowest: compounds 4 and 1 (each within the scatter of the next); then compound 2; then compound 3.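

Replacing 4-nitrophenyl with 1,3-benzoxazol-6-yl gives a 120-fold lower number from compound 3 to compound 4 (2.08 log units; beyond the scatter), even though both groups have the same counts of heavy atoms, hydrogen-bond donors and acceptors and neither carries a net charge, so these counts alone do not separate a high number from a low one at this position. The same group also gives a 4.7-fold lower number from compound 2 to compound 4 (0.67 log units; beyond the scatter), while the comparison with the acid-bearing group gives a 1.1-fold lower number from compound 1 to compound 4 (0.03 log units; within the scatter), which lies within the scatter, so a carboxylic acid is not required on this nitrogen to reach the lowest level seen among these four compounds. No measurement here explains why the fused pair of rings does so much better than either substituted phenyl ring.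

Going by these compounds, it remains open whether the five-membered ring itself matters, or whether a phenyl ring carrying a methoxy group or an amine on the same nitrogen would reach a similar number. The other groups on the shared core are identical in all four compounds, so it is also unknown whether a longer chain in place of the ethyl groups would keep this level.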